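The source may hold more compounds than are shown below. What is called first, only, known or untested is meant among the compounds shown, and "the series" means these compounds.

Three compounds have been measured in a functional assay on MDA-MB-231 cells (Homo sapiens) for antiproliferative activity, read by MTT assay, with a stated time of 72 h; a lower number here means a stronger inhibitor, a higher number a weaker inhibitor:

Compound 1, `CC(C)(C)OC(=O)Nc1ccc(NC(=O)CCc2cccc3c2B(O)OC3)cc1`: 29000 nM
Compound 2, `O=C(CCc1cccc2c1B(O)OC2)Nc1cccc(-c2cccc(F)c2)c1`: 570 nM
Compound 3, `O=C(CCc1cccc2c1B(O)OC2)Nc1cccc(-c2cccc(OC(F)(F)F)c2)c1`: 460 nM

Among these three numbers, compound 2 stands second highest. Its nearest neighbour is compound 3, reached by a 1.2-fold lower number from compound 2 to compound 3 (0.09 log units; within the scatter), a step inside the scatter. Its furthest is compound 1, whose number is far higher than that of compound 2, well beyond the scatter.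

Compound 4, `O=C(CCc1cccc2c1B(O)OC2)Nc1cccc(-c2ccc(C(F)(F)F)cc2)c1`, has not yet been measured. Compared with compound 2 it carries 4-(trifluoromethyl)phenyl in place of 3-fluorophenyl on an aromatic carbon. Among the compounds with values here, the only measured step that bears on this change is a 1.2-fold lower number from compound 2 to compound 3 (0.09 log units; within the scatter), in which a fluoro on the same outer ring of compound 2 gave way to a larger fluorine-bearing group without a change beyond the scatter. The change to compound 4 is of a related kind, though not the same, so the expectation is a step of a 1.1-fold lower number from compound 2 to compound 4 (0.06 log units; within the scatter), that is, no change beyond the scatter. Compound 4 is therefore estimated at 500 nM, with a plausible range from 200 nM to 1500 nM.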

Compound 4, half-maximal inhibitory concentration: 510 nM
The estimate for compound 4 lay 1.0-fold (0.01 log units) below the measured number, within the range that was stated.
By their numbers in this assay, from the lowest: compounds 3, 4 and 2 (each within the scatter of the next); then compound 1.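

In this assay, exchanging 3-fluorophenyl for 4-(trifluoromethyl)phenyl gives a 1.1-fold lower number from compound 2 to compound 4 (0.05 log units; within the scatter). Unlike the earlier step between compounds with a fluorine-bearing outer ring, this change alters both the group and its place on that ring, yet the number stays within the scatter, so this position, on an aromatic carbon and meta to a large group, accepts a second kind of change with no measurable effect here; the two parts of the change cannot be separated, though, as they arrive together. Nothing available explains this result.

As far as these compounds go, all the outer rings compared here carry fluorine, so it remains open whether a plain phenyl ring would give a similar number. An amine or a carboxylic acid on that ring is also untested in what is shown, so the limits of this tolerance are unknown.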